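Compound 3 to compound 4: acetamido to amino

The source may hold more compounds than are shown below. What is called first, only, known or untested is meant among the compounds shown, and "the series" means these compounds.

In an ADME assay on THP-1 cells (Homo sapiens) for cytotoxicity, read by flow cytometry and propidium iodide staining, with a stated time of 72 h (a lower number here means a stronger inhibitor, a higher number a weaker inhibitor), compound 3 `COc1c(-c2ccccc2F)oc2ccc(NC(C)=O)cc2c1=O` gives > 125000 nM, which is a limit and not a number. Compound 1 `CC(=O)Nc1ccc2oc(-c3ccccc3F)cc(=O)c2c1` gives > 125000 nM, which is also a limit. Compound 3 therefore has no exact position, only (the limit of > 125000 nM in this assay, at which 2 of the 3 values shown sit). Among the compounds with values here, the one measured step, a step that the two limits leave unreadable from compound 1 to compound 3, puts methoxy in place of hydrogen on an aromatic carbon and gives no size to carry forward.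

Compound 4 `COc1c(-c2ccccc2F)oc2ccc(N)cc2c1=O` arises from compound 3 through (hydrogen in place of acetyl on a nitrogen on an aromatic ring), hydrogen in place of acetyl on a nitrogen on an aromatic ring. Within the data shown here, compound 2 `Nc1ccc2oc(-c3ccccc3F)c(O)c(=O)c2c1` is the only measured compound with the amino group, and it gives 38000 nM. On this single value, a move to a lower number in this assay is expected, meaning a stronger inhibitor, although another result at the limit remains possible. The expected step is an at least 2.2-fold lower number from compound 3 to compound 4 (0.35 log units; beyond the scatter). For compound 4 the estimated value is 55000 nM, with an expected range of 20000 nM to 125000 nM.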

Compound 4, half-maximal inhibitory concentration: > 125000 nM
Compound 4: no number, only a limit; the forecaster's own chance of this, stated with the estimate: 30%; middle value at least 2.2-fold (0.35 log units) from the limit.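

In this assay compound 4 gives > 125000 nM as a limit and not a number, so the steps that end at a limit on both sides cannot be read. Within the data shown here, the one readable step is an at least 3.2-fold higher number from compound 2 to compound 4 (0.51 log units; beyond the scatter) with methyl in place of hydrogen on an oxygen on an aromatic ring, and this sets the amino compounds apart at that oxygen. Amino in place of acetamido does not by itself bring the methoxy compound to a measurable value, and compound 2 remains the only compound with a number: the limit of > 125000 nM in this assay, at which 3 of the 4 values shown sit.

From the compounds shown here alone, whether ethyl or a longer chain on that oxygen would stay at the limit remains open. So does the reading of a dimethylamino group or a carboxylic acid in place of the amino group on the shared core.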